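This account rests on a few compounds, and the source may have more. Where it says the series, first, only, none or still open, it means among the compounds named here.

Measured so far:
compound 1 `CC1(C(=O)NCCSc2nonc2/C(=N/O)Nc2ccc(F)c(C(F)F)c2)CCN1`: > 3 h
compound 2 `NS(=O)(=O)CC(=O)NCCSc1nonc1/C(=N/O)Nc1cccc(Br)c1`: 0.955 h

In an ADME assay on isolated protein for pharmacokinetics, with UDP-glucuronosyltransferase 1A9 (Homo sapiens) as the target, read by LC-MS, with a stated time of 60 min, at 37 degrees C, tested at 1 uM, in the presence of a further agent that is not named here (on this read-out higher numbers stand for a longer-lived compound and lower numbers for a shorter-lived compound), compound 1 gives > 3 h, which is a limit of the assay and not a number (the limit of > 3 h in this assay, at which 1 of the 2 values shown sits). In this assay compound 2 gives 0.955 h. For the measured compounds named here, these two compounds differ in several places and no single step between them is set out; the pair shows only that compound 1 reaches the limit while compound 2 returns a number.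

Compound 3 `CC(C)(O)CC(=O)NCCSc1nonc1/C(=N/O)Nc1ccc(F)c(C(F)F)c1` differs from compound 1 by a group of 5 heavy atoms (4 carbon, 1 oxygen; no ring) in place of a group of 5 heavy atoms (4 carbon, 1 nitrogen; one four-membered non-aromatic ring with 1 hetero atom), on a carbonyl carbon; in words, a group of 5 heavy atoms (4 carbon, 1 oxygen; no ring) in place of a group of 5 heavy atoms (4 carbon, 1 nitrogen; one four-membered non-aromatic ring with 1 hetero atom), on a carbonyl carbon. Going by the values given here, no measured step of this kind exists, so the expectation rests on compound 1 alone, and compound 1 offers only a limit. The step from compound 1 to compound 3 is expected to be an at least 1.2-fold lower number from compound 1 to compound 3 (0.07 log units; that floor lies within the scatter), that is, toward a somewhat shorter-lived compound, though possibly still within the scatter. Compound 3 is thus estimated at 2.5 h, with a range from 1.2 h to 5 h, and a real chance that the assay again reports only the limit.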

Compound 3, half-life: > 3 h
Compound 3: no number, only a limit (the forecaster's own chance of this, stated with the estimate: 35%); at least 1.2-fold (0.07 log units) between middle value and limit.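

In this assay compound 1 and compound 3 both return a limit and not a number, so no step between them can be read: the limit of > 3 h in this assay, at which 2 of the 3 values shown sit.

On these data alone, it remains open whether the half-life of compound 3, with its 2-hydroxy-2-methylpropyl group, differs from that of compound 1 at all, and in which direction.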